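The source may report more compounds than this note shows. Statements on the series, on what has been measured and on what is new or still open speak of the compounds shown alone.

Working notes on the series.

Compound 1 `N#CC1=C(N)N(c2ccc(S(N)(=O)=O)cc2)C2=C(CCCC2)C1c1ccccc1` is the reference point; in a functional assay on Ehrlich cells (Mus musculus) for cytotoxicity, read by trypan blue exclusion, with a stated time of 2 h, tested at 25 ug/mL (on this read-out higher numbers stand for a stronger effect at the one concentration tested and lower numbers for a weaker effect), compound 1 gives 10%. Compound 2 `N#CC1=C(N)N(c2ccc(S(N)(=O)=O)cc2)C2=C(CCCC2)C1c1ccc([N+](=O)[O-])cc1` carries a nitro in place of hydrogen on an aromatic carbon, and in this assay compound 2 gives 5%, a step of a number 5 percentage points lower from compound 1 to compound 2 (within the scatter). Compound 3 `N#CC1=C(N)N(c2ccc(S(N)(=O)=O)cc2)C2=C(CCCC2)C1c1c(O)ccc2ccccc12` carries a 2-hydroxynaphthalen-1-yl in place of phenyl on a saturated ring carbon; in this assay compound 3 gives 5%. Within the data shown here, the step of a number 5 percentage points lower from compound 1 to compound 3 (within the scatter) and the step of no change at the digits printed from compound 2 to compound 3 (within the scatter) both stay inside the scatter, so compound 3 sits level with compound 2 and within the scatter of compound 1; all three numbers are low and no compound can be set apart from the others.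

Compound 4 `COc1ccc2ccccc2c1C1C(C#N)=C(N)N(c2ccc(S(N)(=O)=O)cc2)C2=C1CCCC2` is not yet measured. It differs from compound 3 by methyl in place of hydrogen on an oxygen on an aromatic ring. Among the measured compounds shown here, no measured step touches this oxygen, so nothing speaks directly to it. What bears on it indirectly is that every measured step, a number 5 percentage points lower from compound 1 to compound 3 (within the scatter) and no change at the digits printed from compound 2 to compound 3 (within the scatter) included, stayed within the scatter at this low level. The expectation for this assay is therefore a step of no change at the digits printed from compound 3 to compound 4 (within the scatter), no change beyond the scatter. Compound 4 is estimated at 5%, expected between 0% and 15%.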

Compound 4, a percentage reported as activity, at one concentration (the size of the read-out at that concentration, not a potency): 10%
Estimate against measurement, compound 4: 5 percentage points below; the range from low to high includes it.
By their numbers in this assay, from the lowest: compounds 2, 3, 1 and 4 (each within the scatter of the next).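

Among these compounds, the change from hydroxy to methoxy, methyl in place of hydrogen on an oxygen on an aromatic ring, is the first measured change at this oxygen, and in this assay it gives a number 5 percentage points higher from compound 3 to compound 4 (within the scatter). Among the compounds shown here, the hydrogen on this oxygen is therefore not needed to hold the read-out at this low level, and a single added carbon there does not move the number beyond the scatter, which the earlier compounds could not show because none of them differed at this oxygen. No measurement of any property is at hand that bears on this result.

On these data alone, a single pair cannot show whether this oxygen tolerates any change, so it stays open whether a longer chain such as butyl, an acetyl group or a chain ending in an amine or a carboxylic acid on this oxygen would give a step beyond the scatter. As far as these compounds go, with every number low and taken at one concentration, it also stays open whether hydroxy and methoxy would separate at other concentrations or on a compound with a stronger effect.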